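The source may report more compounds than this note shows. Statements on the series, on what has been measured and on what is new or still open speak of the compounds shown alone.

Notes on the series. Compound 3 `COc1cc(-c2nn(-c3cccc(NC(=O)c4cccc(C(F)(F)F)c4)c3)cc2-c2ccncc2)ccc1Cl` gives 2280 nM in a functional assay on OVCAR-4 cells (Homo sapiens) for inhibition, read by sulforhodamine B assay, with a stated time of 48 h (a lower number here means a stronger inhibitor of growth, a higher number a weaker inhibitor of growth), the second highest of the three numbers in hand. Compound 1 `O=C(Nc1cccc(-n2cc(-c3ccncc3)c(-c3ccc(Cl)c(O)c3)n2)c1)Nc1ccc(Cl)c(Cl)c1` gives 1690 nM, within the scatter of compound 3. For the measured compounds named here, compound 2 `COc1cc(-c2nn(-c3cccc(NC(=O)c4ccc(Cl)c(C(F)(F)F)c4)c3)cc2-c2ccncc2)ccc1Cl` gives 8040 nM; the one step measured between compounds differing in a single place, a 3.5-fold lower number from compound 2 to compound 3 (0.55 log units; beyond the scatter), is the only change in the set beyond the scatter. Compound 4 `COc1cc(-c2nn(-c3cccc(NC(=O)Nc4cccc(C(F)(F)F)c4)c3)cc2-c2ccncc2)ccc1Cl` differs from compound 3 in one place: (3-(trifluoromethyl)phenyl)amino in place of 3-(trifluoromethyl)phenyl on a carbonyl carbon. Going by the values given here, no measured step covers this change, and compound 1 differs from compound 4 in several places, so it gives no direct guide. The step of a 1.1-fold lower number from compound 3 to compound 4 (0.06 log units; within the scatter) is therefore expected to stay within the scatter. Compound 4 is estimated at 2000 nM, in the range 700 nM to 6000 nM.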

Compound 4, concentration for 50% growth inhibition: 1100 nM
Compound 4: the middle estimate sits 1.8-fold (0.26 log units) above what was measured, and the stated range covers the measured number.
By their numbers in this assay, from the lowest: compounds 4, 1 and 3 (each within the scatter of the next, the first and the last beyond it); then compound 2.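

At this carbonyl carbon, (3-(trifluoromethyl)phenyl)amino in place of 3-(trifluoromethyl)phenyl moves this assay beyond the scatter, with a 2.1-fold lower number from compound 3 to compound 4 (0.32 log units; beyond the scatter), so the group attached to the carbonyl matters here as well as the chloro on the aromatic ring. Replacing 4-chloro-3-(trifluoromethyl)phenyl with the same group gives a 7.3-fold lower number from compound 2 to compound 4 (0.86 log units; beyond the scatter). No supporting data bear on the origin of either step.

Going by these compounds, whether a methylamino link or an oxygen link, as in a carbamate, would be tolerated at this carbonyl carbon remains open.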